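Methoxy on the fused ring: cytotoxicity notes on the series

This account rests on a few compounds, and the source may have more. Where it says the series, first, only, none or still open, it means among the compounds named here.

Compound 1 `CC(=O)OC[C@H]1O[C@@H](n2c(SCc3cc4ccccc4oc3=O)nc3cncnc32)[C@H](O)[C@@H]1O` and compound 2 `COc1cccc2cc(CSc3nc4cncnc4n3[C@@H]3O[C@H](COC(C)=O)[C@@H](O)[C@H]3O)c(=O)oc12` share one core; compound 2 differs from compound 1 by methoxy in place of hydrogen on an aromatic carbon. In a functional assay on Huh-5-2 cells (Homo sapiens) for cytotoxicity, read by microscopy (on this read-out higher numbers stand for lower toxicity in this test and lower numbers for higher toxicity in this test), compound 1 gives 8700 nM and compound 2 gives 11000 nM; the step is a 1.3-fold higher number from compound 1 to compound 2 (0.10 log units; within the scatter).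

Compound 3 `Nc1ncnc2c1nc(SCc1cc3ccccc3oc1=O)n2[C@@H]1O[C@H](CO)[C@@H](O)[C@H]1O` has a different core; the difference between the two cores is not broken down here. In this assay compound 3 gives 49000 nM, which stands beyond the scatter from both compound 1 and compound 2.

Compound 4 `COc1cccc2cc(CSc3nc4c(N)ncnc4n3[C@@H]3O[C@H](CO)[C@@H](O)[C@H]3O)c(=O)oc12` differs from compound 3 by methoxy in place of hydrogen on an aromatic carbon. The place of this change is the same, word for word, as the place of the change from compound 1 to compound 2, so it is the same change, made on the other core. It has been measured once, and that step sat within the scatter.

For compound 4 the expected step is a 1.2-fold higher number from compound 3 to compound 4 (0.09 log units; within the scatter), resting on a 1.3-fold higher number from compound 1 to compound 2 (0.10 log units; within the scatter). Compound 4 is therefore estimated at 60000 nM, with a range from 30000 nM to 120000 nM expected.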

Compound 4, half-maximal cytotoxic concentration: > 103000 nM
Compound 4 ended at the assay's limit; the forecaster's own chance of this, stated with the estimate: 25%; middle value at least 1.7-fold (0.23 log units) from the limit.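

Working notes on carrying the change across cores: on the core of compound 3, methoxy in place of hydrogen on an aromatic carbon gives an at least 2.1-fold higher number from compound 3 to compound 4 (0.32 log units; beyond the scatter) in this assay. For compound 4, the reading of > 103000 nM is a limit of the assay and not a number. The same change thus lies beyond the scatter on one core and within it on the other, but this does not show that its effect on the read-out depends on the core: the same change on two cores in this assay, a 1.3-fold higher number (0.10 log units; within the scatter) from compound 1 to compound 2 and an at least 2.1-fold higher number (0.32 log units; beyond the scatter) from compound 3 to compound 4; the limit leaves it open whether they differ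

The compounds shown leave open the true size of the step on the core of compound 3, and whether an amine or a longer alkoxy chain in place of the methoxy would give a similar reading on either core. Within the data shown here, with only two matched pairs, they also leave open how the methoxy change would behave on any further core.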